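Inversion of a ring stereocentre between compound 2 and compound 3

This account rests on a few compounds, and the source may have more. Where it says the series, first, only, none or still open, it means among the compounds named here.

Measured so far:
- compound 1, `Cc1ccc(N2CCN(C(=O)[C@@H]3CCO[C@@H]3c3ccc(Cl)cc3)CC2)c([C@@H](NC(=O)CCN(C)C)C(C)C)c1`: 120 nM in an assay on HEK293 cells for displacement of a labelled ligand from Melanocortin receptor 4 (Homo sapiens); a higher number here means a weaker inhibitor, a lower number a stronger inhibitor
- compound 2, `Cc1ccc(N2CCN(C(=O)[C@H]3OCC[C@@H]3c3ccc(Cl)cc3)CC2)c([C@@H](NC(=O)CCN(C)C)C(C)C)c1`: 43 nM in this assay

Compound 2 gives the lowest number of the two measured in this assay; the nearest is compound 1, and the step of a 2.8-fold lower number from compound 1 to compound 2 (0.45 log units; beyond the scatter) lies beyond the scatter. For the measured compounds named here, that step exchanges 2-(4-chlorophenyl)oxolan-3-yl for 3-(4-chlorophenyl)oxolan-2-yl on the carbonyl carbon and is the only measured step.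

Compound 3, `Cc1ccc(N2CCN(C(=O)[C@@H]3OCC[C@@H]3c3ccc(Cl)cc3)CC2)c([C@@H](NC(=O)CCN(C)C)C(C)C)c1`, is the unmeasured partner. Relative to compound 2, (the two compounds have the same atoms and bonds and differ only in configuration as drawn: 1 of 3 stereo elements differ; a stereocentre at a saturated ring carbon is drawn S in compound 2 and R in compound 3). Going by the values given here, no measured step alters a stereocentre, so the step from compound 1 to compound 2 bears only indirectly: it shows that how the chlorophenyl-bearing group is arranged changes the number by a modest amount. Compound 2 stands lowest, so a change of configuration seems more likely to raise the number than to lower it, though the direction is uncertain. The expected step is a 3.5-fold higher number from compound 2 to compound 3 (0.54 log units; beyond the scatter). Compound 3 is estimated at 150 nM in this assay, with a range from 30 nM to 800 nM.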

Compound 3, inhibition constant: 10 nM
Compound 3: the middle estimate sits 15-fold (1.18 log units) above what was measured, outside the stated range (below it).
By their numbers in this assay, from the lowest: compound 3; then compound 2; then compound 1.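

In this assay, the configuration at a saturated ring carbon now has a measured effect of its own, a 4.3-fold lower number from compound 2 to compound 3 (0.63 log units; beyond the scatter), and this step can be assigned to configuration alone because nothing else separates the pair: the fact that compounds 2 and 3 differ only in the configuration as drawn

The earlier pair showed only a modest change when 3-(4-chlorophenyl)oxolan-2-yl replaced 2-(4-chlorophenyl)oxolan-3-yl, whereas the same exchange with this ring carbon drawn R gives a 12-fold lower number from compound 1 to compound 3 (1.08 log units; beyond the scatter), so the size of the change depends on the configuration that accompanies the exchange. Compound 3, at 10 nM, now has the lowest number of the three, and its steps to both other compounds are beyond the scatter.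

The compounds shown leave open how the two other stereo elements contribute and whether the lower number with the R drawing persists when 4-chlorophenyl gives way to 4-fluorophenyl or 4-methoxyphenyl. Also open, from the compounds shown here alone, is whether this configuration keeps its advantage when the dimethylamino group at the end of the amide side chain is replaced by a primary amine or a pyrrolidine.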